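A few compounds are considered here, and "the series" means these few. Any claim that something is new, unique, unknown or untested is made for them only; others in the source may bear on it.

Compound 1 `N#Cc1ccc(Nc2nccc(NC3CCCCC3)n2)cc1` and compound 2 `N#Cc1ccc(Nc2nccc(OC3CCCC3)n2)cc1` share one core and differ in a single group. In an ADME assay on MT4 cells (Homo sapiens) for cytotoxicity, read by MTT assay (a lower number here means that less compound is tolerated, a higher number that more compound is tolerated), compound 1 gives 7330 nM. Compound 2 reaches only a limit of the assay, >= 339000 nM, so compound 2 stands at the top edge of the numbers shown (the limit of >= 339000 nM in this assay, at which 1 of the 2 values shown sits). Between them lies the step of an at least 46-fold higher number from compound 1 to compound 2 (1.66 log units; beyond the scatter). Compound 3 `N#Cc1ccc(Nc2nccc(NC3CC3)n2)cc1` has not yet been measured in this assay. It differs from compound 2 by cyclopropylamino in place of cyclopentyloxy on an aromatic carbon. Within the data shown here, the only measured step that bears on this change is an at least 46-fold higher number from compound 1 to compound 2 (1.66 log units; beyond the scatter), in which cyclohexylamino gave way to cyclopentyloxy and the number rose strongly; the change to compound 3 brings an amino group back, now as cyclopropylamino. The expected change is therefore estimated as an at least 6.7-fold lower number from compound 2 to compound 3 (0.83 log units; beyond the scatter). Compound 3 is estimated at 50000 nM, within a range from 8000 nM to 300000 nM.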

Compound 3, half-maximal cytotoxic concentration: 1190 nM
For compound 3 the middle estimate is 42-fold (1.62 log units) above the measured one, and the stated range ends above it.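

With the amino link kept and only the ring on the nitrogen changed, this assay shows a 6.2-fold lower number from compound 1 to compound 3 (0.79 log units; beyond the scatter), so the ring on that nitrogen alone shifts the number, and here the smaller ring goes with less compound being tolerated. The step of an at least 280-fold lower number from compound 2 to compound 3 (2.45 log units; beyond the scatter) swaps the linking atom and the ring together, and its size is only a bound, since compound 2 stands at a limit: the limit of >= 339000 nM in this assay, at which 1 of the 3 values shown sits. Among these three compounds, the two with an amino link both give lower numbers than the one with an oxygen link, and none goes against this.

A cyclopentylamino group or a cyclohexyloxy group would be needed to separate the effect of the linking atom from that of ring size. Going by these compounds, whether an open chain such as isopropylamino follows the rings remains open.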